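Cytotoxicity notes: pyridine in place of fluorophenyl

The compounds below may be only part of what the source reports. "The series", "measured", "known", "first", "only" and "open" are said of these compounds alone.

Compound 1 `Cc1nc2c(c(-c3cc(F)c4c(c3C)CCCO4)c1[C@H](OC(C)(C)C)C(=O)O)CN(CCCc1ccc(F)cc1)CC2` in an ADME assay on MT2 cells (Homo sapiens) for cytotoxicity, read by XTT assay, with a stated time of 4 days; on this read-out higher numbers stand for lower toxicity in this test and lower numbers for higher toxicity in this test: > 40000 nM
Compound 2 `CCCCCN1CCc2nc(C)c(C(OC(C)(C)C)C(=O)O)c(-c3ccc(C)cc3)c2C1`: > 40000 nM
Compound 3 `Cc1ccc(-c2c3c(nc(C)c2[C@H](OC(C)(C)C)C(=O)O)CCN(C(=O)NCc2ccccc2)C3)cc1`: > 40000 nM

Each of these three values is a limit of the test, not a measured number. Among the measured compounds shown here, compound 1 stands at that limit, as the line the limit of > 40000 nM in this assay, at which 3 of the 3 values shown sit, shows, and the other two entries give no number either, so no spread among the measured compounds can be read and no step between any two of them is on record.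

Compound 4 `Cc1nc2c(c(-c3cc(F)c4c(c3C)CCCO4)c1[C@H](OC(C)(C)C)C(=O)O)CN(CCCc1ccncc1)CC2` has not yet been run. It departs from compound 1 in one place, (pyridin-4-yl in place of 4-fluorophenyl on a saturated chain carbon, three bonds along the chain from an amine nitrogen in a ring). For the measured compounds named here, no measured pair shows the effect of such a change, so the expectation for compound 4 rests on compound 1 alone. Since compound 1 sits at the limit, any step in this assay from compound 1 to compound 4 is expected to be none beyond the scatter, expected as a number no higher from compound 1 to compound 4 (the limit leaves the size open). Compound 4 is accordingly expected at 40000 nM, with an expected range from 20000 nM to 80000 nM, and the test is expected most likely to return a limit again rather than a number.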

Compound 4, half-maximal cytotoxic concentration: > 40000 nM
Compound 4: a limit, no number; the forecaster's own chance of this, stated with the estimate: 85%; the middle value sits exactly at the limit.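

No step can be read between compound 1 and compound 4 in this assay, as both values are limits rather than numbers: the limit of > 40000 nM in this assay, at which 4 of the 4 values shown sit.

The compounds shown leave open at what concentration any of them would turn cytotoxic, and whether pyridin-4-yl in place of 4-fluorophenyl alters that concentration.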